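This account rests on a few compounds, and the source may have more. Where it says the series, first, only, none or still open, it means among the compounds named here.

Compound 1 `CCCCCCCOc1ccc(NC(=O)Oc2ccccc2F)cc1` gives 28 nM in an assay on H4 cells for inhibition of Fatty-acid amide hydrolase 1 (Homo sapiens); on this read-out higher numbers stand for weaker inhibition and lower numbers for stronger inhibition.
Compound 2 `CCCCCCCOc1ccc(NC(=O)O/N=C/c2ccccc2)cc1` gives 8.6 nM in this assay.

Compound 1 stands highest of these two numbers; its nearest neighbour is compound 2, with a 3.3-fold lower number from compound 1 to compound 2 (0.51 log units; beyond the scatter). Compound 3 `CCCCCCCCCCOc1ccc(NC(=O)Oc2ccccc2F)cc1` differs from compound 1 by propyl in place of hydrogen on a saturated chain carbon, seven bonds along the chain from an oxygen on an aromatic ring, a change on the saturated chain. Going by the values given here, the only measured step alters the group on the oxygen next to the carbonyl, so it does not bear on lengthening the chain, and no step beyond the usual scatter is expected; the estimated step is a 1.3-fold lower number from compound 1 to compound 3 (0.10 log units; within the scatter). Compound 3 is estimated at 22 nM, within 7 nM to 70 nM.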

Compound 3, half-maximal inhibitory concentration: 9.2 nM
Estimate against measurement, compound 3: 2.4-fold (0.38 log units) above; the measured number falls inside the stated range.
By their numbers in this assay, from the lowest: compounds 2 and 3 (each within the scatter of the next); then compound 1.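

Lengthening the saturated chain with propyl, seven bonds along the chain from an oxygen on an aromatic ring, gives a 3.0-fold lower number from compound 1 to compound 3 (0.48 log units; beyond the scatter) in this assay. So the chain is a second place where a change moves the number, separate from the group altered in the earlier step. Nothing measured here explains why the number drops.

As far as these compounds go, whether a longer chain would lower the number further remains open. So does whether an amine or a carboxylic acid at the end of the chain would keep this gain.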